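A few compounds are considered here, and "the series" means these few. Any claim that something is new, unique, unknown or untested is made for them only; others in the source may bear on it.

Cytotoxicity across the series is followed in an ADME assay on HEK293-A cells (Homo sapiens) for cytotoxicity, read by MTT assay, with a stated time of 48 h; a higher number here means a weaker inhibitor, a lower number a stronger inhibitor. Compound 1 `CN(CCC#N)C[C@H]1CN(c2ccc(-n3cc(-c4ccccn4)cn3)c(F)c2)C(=O)O1` gives in this assay > 400 ug/mL, which is a limit of the assay. Compound 2 `O=C1O[C@@H](CN2CCC(O)CC2)CN1c1ccc(-n2cc(-c3ccccn3)cn2)c(F)c1` gives in this assay > 400 ug/mL, again a limit. Compound 3 `O=C1O[C@@H](CNC(=O)C(F)(F)F)CN1c1ccc(-n2cc(-c3ccccn3)cn2)c(F)c1` gives in this assay > 400 ug/mL, also a limit. Compound 2 therefore stands where every measured member stands, because of the limit of > 400 ug/mL in this assay, at which 3 of the 3 values shown sit. The steps a step that the two limits leave unreadable from compound 1 to compound 2, a step that the two limits leave unreadable from compound 1 to compound 3 and a step that the two limits leave unreadable from compound 2 to compound 3 cannot be sized because of the limit of > 400 ug/mL in this assay, at which 3 of the 3 values shown sit.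

Compound 4 `CONC(=O)[C@H]1CN(c2ccc(-n3cc(-c4ccccn4)cn3)c(F)c2)C(=O)O1` is not yet measured. Relative to compound 2 the change is methoxycarbamoyl in place of (4-hydroxypiperidin-1-yl)methyl on a saturated ring carbon. Within the data shown here, no measured step bears on this change in a readable way: the three known steps are all unreadable and give neither size nor direction. What the measured set does show is that three different groups on the saturated chain carbon bound to a saturated ring carbon of the shared core all leave the value at the limit (the limit of > 400 ug/mL in this assay, at which 3 of the 3 values shown sit). The expectation for compound 4 is therefore no step beyond the scatter, a number no higher from compound 2 to compound 4 (the limit leaves the size open), with this assay most likely again reporting only a limit. Compound 4 is estimated at 400 ug/mL, with a range from 200 ug/mL to 800 ug/mL.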

Compound 4, half-maximal inhibitory concentration: > 400 ug/mL
Compound 4 gave a limit, no number; the forecaster's own chance of this, stated with the estimate: 85%; the middle value sits exactly at the limit.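

No new step can be read: the steps from compound 1, compound 2 and compound 3 to compound 4 all join two limits in this assay, and their size stays unknown: the limit of > 400 ug/mL in this assay, at which 4 of the 4 values shown sit.

The compounds shown leave open how far methoxycarbamoyl or any of the other groups shifts cytotoxicity, since no member of this set gives an actual number in this assay.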